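Shortening the Amide Substituent on a Shared Indole Core

The source may report more compounds than this note shows. Statements on the series, on what has been measured and on what is new or still open speak of the compounds shown alone.

Three measured compounds share one core and differ only in the group on the carbonyl carbon of the amide. Compound 1 `CCCCCCCC(=O)Nc1ccc2[nH]cc(C3CCN(C)CC3)c2n1` carries a heptyl group and gives 20 nM in an assay for binding affinity to 5-hydroxytryptamine receptor 1F (Homo sapiens), read by radioligand binding; on this read-out higher numbers stand for weaker inhibition and lower numbers for stronger inhibition. Compound 2 `CN1CCC(c2c[nH]c3ccc(NC(=O)C4CC4)nc23)CC1` carries a cyclopropyl group and gives 9.8 nM in this assay. Compound 3 `Cc1cccc(C(=O)Nc2ccc3[nH]cc(C4CCN(C)CC4)c3n2)c1` carries a 3-methylphenyl group and gives 5.8 nM in this assay, the lowest of the three numbers; its step to compound 2 lies within the scatter, while a 3.4-fold lower number from compound 1 to compound 3 (0.54 log units; beyond the scatter). The step of a 2.0-fold lower number from compound 1 to compound 2 (0.31 log units; beyond the scatter) is the only other one that bears on a shortened chain.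

Compound 4 `CCCCC(=O)Nc1ccc2[nH]cc(C3CCN(C)CC3)c2n1` differs from compound 3 in one place: butyl in place of 3-methylphenyl on a carbonyl carbon. For the measured compounds named here, no measured step compares a butyl group directly with either the heptyl or the 3-methylphenyl group, so the expectation rests on the spread of the three numbers. A butyl chain would be expected to land between compound 1 and compound 3, and compound 4 is therefore estimated at 12 nM (range 4 nM to 40 nM), which means an expected step of a 2.1-fold higher number from compound 3 to compound 4 (0.32 log units; beyond the scatter).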

Compound 4, inhibition constant: 14 nM
Compound 4: the middle estimate sits 1.2-fold (0.07 log units) below what was measured, and the stated range covers the measured number.
By their numbers in this assay, from the lowest: compounds 3, 2, 4 and 1 (each within the scatter of the next, the first and the last beyond it).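

In this assay, butyl separates from only one of the other three groups: a 2.4-fold higher number from compound 3 to compound 4 (0.38 log units; beyond the scatter), whereas a 1.4-fold higher number from compound 2 to compound 4 (0.15 log units; within the scatter) and a 1.4-fold lower number from compound 1 to compound 4 (0.15 log units; within the scatter) both stay within the scatter. On this carbonyl carbon, then, the shorter butyl chain cannot be told apart from heptyl or from cyclopropyl, so shortening heptyl to butyl brings no change beyond the scatter, and only the group with the aromatic ring stands clear of butyl. Nothing in the data explains why the 3-methylphenyl and butyl groups differ.

The compounds shown leave open whether the methyl group of 3-methylphenyl contributes, which an unsubstituted phenyl group would test. They also leave open how a chain carrying an amine or a carboxylic acid would read at this position.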